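Fluoro to cyano on the fused aromatic ring

The compounds below may be only part of what the source reports. "The series", "measured", "known", "first", "only" and "open" are said of these compounds alone.

For the measured compounds named here, compound 2 `C[C@H]1CN(c2cccc3cc(F)ccc23)CCN1CC[C@H]1OCc2cc(C(N)=O)ccc21` gives 43 nM in an assay on cell membranes for displacement of a labelled ligand from Adrenergic receptor alpha-1 (Rattus norvegicus) (a lower number here means a stronger inhibitor, a higher number a weaker inhibitor), and stands at the lowest of the two numbers measured so far. Its nearest neighbour, compound 1 `C[C@H]1CN(c2cccc3cc(F)ccc23)CCN1CC[C@@H]1OCc2cc(C(N)=O)ccc21`, gives 64 nM in this assay; the step of a 1.5-fold lower number from compound 1 to compound 2 (0.17 log units; within the scatter) rests on the fact that compounds 1 and 2 differ only in the configuration as drawn and stays within the scatter.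

Compound 3 `C[C@H]1CN(c2cccc3cc(C#N)ccc23)CCN1CC[C@H]1OCc2cc(C(N)=O)ccc21` is not yet measured. It differs from compound 2 by cyano in place of fluoro on an aromatic carbon. Going by the values given here, none of the measured steps touches this position: the single step on record is a change of configuration and says nothing about the substituent on the ring. No direction beyond the scatter is therefore expected, though a moderate step either way cannot be excluded. For compound 3 the expected step is a 1.2-fold higher number from compound 2 to compound 3 (0.07 log units; within the scatter). Compound 3 is estimated at 50 nM in this assay, with a range from 15 nM to 160 nM.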

Compound 3, inhibition constant: 338 nM
For compound 3 the middle estimate is 6.8-fold (0.83 log units) below the measured one, and the stated range ends below it.
By their numbers in this assay, from the lowest: compounds 2 and 1 (each within the scatter of the next); then compound 3.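

Unlike the change of configuration, the change of substituent on this aromatic carbon has a clear effect in this assay: cyano in place of fluoro gives a 7.9-fold higher number from compound 2 to compound 3 (0.90 log units; beyond the scatter). For the compounds shown here, this is the only step on record that lies beyond the scatter, so this position responds to the group it carries, at least for this pair, and one pair sets no trend across substituents. Nothing on record bears on why the number rises with this change.

As far as these compounds go, whether other groups at this position, such as chloro, methoxy or an amine, stay close to fluoro or move the number as cyano does remains open. From the compounds shown here alone, it is also open whether cyano in place of fluoro gives a step of similar size on the configuration drawn in compound 1.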